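Swapping the nitrophenyl for thiophene on the chalcone

This account rests on a few compounds, and the source may have more. Where it says the series, first, only, none or still open, it means among the compounds named here.

In a functional assay on HepG2 cells (Homo sapiens) for antiproliferative activity, read by MTT assay, with a stated time of 24 h (on this read-out higher numbers stand for weaker inhibition and lower numbers for stronger inhibition), compound 3 `COc1ccc(C(=O)/C=C/c2ccc([N+](=O)[O-])cc2)c2c1C=CC(C)(C)O2` gives 2610 nM, the higher of the two numbers on hand. Its nearest neighbour, compound 2 `CCN(CC)c1ccc(/C=C/C(=O)c2ccc(OC)c3c2OC(C)(C)C=C3)cc1`, gives 590 nM. Compound 1 `COc1ccc(C(=O)/C=C/c2ccc(-c3ccccc3)cc2)c2c1C=CC(C)(C)O2` reaches only a limit of the assay, > 10000 nM (the limit of > 10000 nM in this assay, at which 1 of the 3 values shown sits). Compound 4 `COc1ccc(C(=O)/C=C/c2cccs2)c2c1C=CC(C)(C)O2` differs from compound 3 in one place: thiophen-2-yl in place of 4-nitrophenyl on a double-bonded chain carbon bound to a double-bonded chain carbon. The measured steps, an at least 3.8-fold lower number from compound 1 to compound 3 (0.58 log units; beyond the scatter) and a 4.4-fold higher number from compound 2 to compound 3 (0.65 log units; beyond the scatter), change only the group carried on the six-membered aromatic ring of carbon only; neither replaces that ring itself, so they bear loosely on this change. A shift in either direction, within the scatter or modestly beyond it, is plausible. Compound 4 is therefore expected to give about 3000 nM, between 1000 nM and 10000 nM, meaning a 1.1-fold higher number from compound 3 to compound 4 (0.06 log units; within the scatter).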

Compound 4, half-maximal inhibitory concentration: > 10000 nM
Compound 4 was reported as a limit (the forecaster's own chance of this, stated with the estimate: 20%); middle value at least 3.3-fold (0.52 log units) from the limit.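

In this assay, for the compounds shown here, the earlier steps changed only the group carried on the six-membered aromatic ring, whereas here the ring itself is replaced: thiophen-2-yl in place of 4-nitrophenyl gives an at least 3.8-fold higher number from compound 3 to compound 4 (0.58 log units; beyond the scatter). For this pair, then, one aromatic ring cannot simply stand in for another at this place. Compound 4 is reported only as a limit, so the full size of the change stays unknown: the limit of > 10000 nM in this assay, at which 2 of the 4 values shown sit.

On these data alone, it remains open whether a pyridine or furan ring here would behave like the 4-nitrophenyl of compound 3 or the thiophen-2-yl of compound 4. As far as these compounds go, it is also open whether a diethylamino group on the thiophene would lower the number, as it does on the six-membered ring.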